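From methyl to acetyl on a ring nitrogen

This account rests on a few compounds, and the source may have more. Where it says the series, first, only, none or still open, it means among the compounds named here.

Compound 1 `Cc1c2c(n3c1CCNC[C@@H](C)[C@H](C)Nc1cc-3ccc1C(N)=O)CC(C)(C)CC2=O` and compound 2 `Cc1c2c(n3c1CCN(C)C[C@@H](C)[C@H](C)Nc1cc-3ccc1C(N)=O)CC(C)(C)CC2=O` differ in a single group, and both were tested in a functional assay on NCI-H1975 cells (Homo sapiens) for antiproliferative activity; on this read-out lower numbers stand for stronger inhibition and higher numbers for weaker inhibition. In this test compound 1 gives 27 nM and compound 2 gives 27 nM. Compound 2 therefore stands level with compound 1, its nearest neighbour on these numbers.

The next structure, compound 3 `CC(=O)N1CCc2c(C)c3c(n2-c2ccc(C(N)=O)c(c2)N[C@@H](C)[C@H](C)C1)CC(C)(C)CC3=O`, keeps the shared core and alters that same nitrogen: acetyl in place of methyl on an amine nitrogen in a ring.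

For the measured compounds named here, only one measured step bears on this change: no change at the digits printed from compound 1 to compound 2 (within the scatter), which placed methyl on that nitrogen in place of hydrogen and left the value unchanged. Going by the values given here, that step shows that a methyl group is tolerated there, but no compound with acetyl on this nitrogen has been measured, so it is only a loose guide. A small loss of inhibition in this assay is expected, and it may not exceed the scatter. The estimated step is a 1.5-fold higher number from compound 2 to compound 3 (0.17 log units; within the scatter). For compound 3 the expected value is 40 nM, with an estimated range of 13 nM to 130 nM.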

Compound 3, half-maximal inhibitory concentration: 15 nM
Compound 3: the middle estimate sits 2.7-fold (0.43 log units) above what was measured; the measured number falls inside the stated range.
By their numbers in this assay, from the lowest: compounds 3, 1 and 2 (each within the scatter of the next).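

In this assay, this ring nitrogen has now been read with three groups on it: replacing methyl with acetyl gives a 1.8-fold lower number from compound 2 to compound 3 (0.26 log units; within the scatter) and replacing hydrogen with acetyl gives a 1.8-fold lower number from compound 1 to compound 3 (0.26 log units; within the scatter) in the same test. Until now only methyl had been compared with hydrogen at this nitrogen, whereas compound 3 shows that the position also accepts acetyl, with 3 heavy atoms against 1 for methyl and 1 hydrogen-bond acceptor against 0, with no loss of inhibition beyond the scatter. Among compounds 1, 2 and 3, therefore, this read-out does not separate hydrogen, methyl and acetyl on this nitrogen, so none of the three can be ranked above the others.

The data shown offer no explanation for why the three compounds read so much alike. From the compounds shown here alone, it remains open whether a longer acyl chain such as propanoyl, a methanesulfonyl group or a chain ending in a carboxylic acid on this same nitrogen would also stay within the scatter, or whether one of them would finally move the number.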